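Hydroxyalkyl thioether chains: shortening and branching

This account rests on a few compounds, and the source may have more. Where it says the series, first, only, none or still open, it means among the compounds named here.

Compound 1 `CC1=C(SCCCCO)C(=O)c2ccccc2C1=O`: in a functional assay on Detroit 551 cells (Homo sapiens) for inhibition (a higher number here means a weaker inhibitor, a lower number a stronger inhibitor), compound 1 gives 7570 nM.
Compound 2 `CC1=C(SCCCCCCO)C(=O)c2ccccc2C1=O`: in this assay compound 2 gives only a limit, > 10000 nM.

Compound 2 sits at the assay limit (the limit of > 10000 nM in this assay, at which 1 of the 2 values shown sits), so no number is known for it, only that it lies past that point. Compound 3 `CC1=C(SC(C)C(C)O)C(=O)c2ccccc2C1=O` differs from compound 2 in one place: 2-hydroxy-1-methylpropyl in place of 6-hydroxyhexyl on a sulfur. Among the compounds with values here, the only measured step, an at least 1.3-fold higher number from compound 1 to compound 2 (0.12 log units; that floor lies within the scatter), concerns chain length in the other direction, and its floor lies within the scatter, so it gives little guidance on a shorter, branched chain. With compound 2 at a limit, the change can only be guessed at. The expected step is an at least 1.6-fold lower number from compound 2 to compound 3 (0.22 log units; that floor lies within the scatter). For compound 3 the expected value is 6000 nM, within 2000 nM to 20000 nM. That would place it near compound 1, which gives 7570 nM in this assay.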

Compound 3, half-maximal inhibitory concentration: > 10000 nM
Compound 3: no number, only a limit; the forecaster's own chance of this, stated with the estimate: 35%; at least 1.6-fold (0.22 log units) between middle value and limit.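

The shorter, branched chain does not bring the series into a measurable range, and in this assay compound 3, like compound 2, stands only at a limit: the limit of > 10000 nM in this assay, at which 2 of the 3 values shown sit. Against the 4-hydroxybutyl chain, the 2-hydroxy-1-methylpropyl chain gives an at least 1.3-fold higher number from compound 1 to compound 3 (0.12 log units; that floor lies within the scatter), so the real size of this change stays unfixed. The step between compound 2 and compound 3 cannot be read, as both are limits, and of the three compounds only compound 1 gives a number.

Branching and chain length are changed together in compound 3, so their separate contributions remain open. Also open, on these data alone, is whether an amine or a carboxylic acid in place of the hydroxy would give a measurable value on the shared core.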